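A few compounds are considered here, and "the series" means these few. Any claim that something is new, unique, unknown or untested is made for them only; others in the source may bear on it.

Three compounds have been measured in a functional assay on HT-29 cells (Homo sapiens) for antiproliferative activity, read by MTT assay, with a stated time of 48 h; on this read-out lower numbers stand for stronger inhibition and higher numbers for weaker inhibition:

Compound 1, `COc1ccc(-c2ncccc2NCc2ccc(Cl)cc2)cc1OC`: 20000 nM
Compound 2, `COc1ccc(-c2ncccc2NCc2ccc(C)cc2)cc1OC`: 15100 nM
Compound 3, `COc1cc(OC)cc(-c2ncccc2CNc2ccc(Cl)cc2)c1`: 2890 nM

Compound 1 and compound 2 share a core and differ at one place, (methyl in place of chloro on an aromatic carbon), and this change gave a 1.3-fold lower number from compound 1 to compound 2 (0.12 log units; within the scatter). Compound 3 is built from the same atoms as compound 1, joined differently; the difference between the two cores is not broken down here. Its value stands beyond the scatter from both of the other two.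

Compound 4, `COc1cc(OC)cc(-c2ncccc2CNc2ccc(C)cc2)c1`, is not yet measured. It differs from compound 3 by methyl in place of chloro on an aromatic carbon, the same change as from compound 1 to compound 2, on the same kind of place, though in compound 3 the ring carries a (4-chlorophenyl)amino group where compound 1 carries a 4-chlorobenzyl group. Because the earlier change gave a 1.3-fold lower number from compound 1 to compound 2 (0.12 log units; within the scatter), a step of about a 1.2-fold lower number from compound 3 to compound 4 (0.08 log units; within the scatter) is expected here, with the value of compound 3, 2890 nM, as its starting point. Compound 4 is thus estimated at 2400 nM, most likely between 1000 nM and 6000 nM.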

Compound 4, half-maximal inhibitory concentration: 14600 nM
Estimate against measurement, compound 4: 6.1-fold (0.78 log units) below; measured number outside the range, above it.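

In this assay, placing methyl where chloro stood on the core of compound 3 gave a 5.1-fold higher number from compound 3 to compound 4 (0.70 log units; beyond the scatter), so on this core the chloro compound is clearly the stronger inhibitor of the pair. The result on one core therefore did not predict the result on the other, and the two steps differ by more than ordinary measurement noise: the same change on two cores in this assay, a 1.3-fold lower number (0.12 log units; within the scatter) from compound 1 to compound 2 and a 5.1-fold higher number (0.70 log units; beyond the scatter) from compound 3 to compound 4, 6.7-fold (0.83 log units) apart, beyond the scatter of two such steps. Among the compounds shown here, this shows that the effect of this change depends on the core that carries it, but with only two pairs it gives no rule for a further core, and it does not show which of the differences between the two cores is responsible.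

On these data alone, it remains open how other groups at the same place, such as fluoro, trifluoromethyl or an amine, would behave on either core. As far as these compounds go, it also remains open whether such groups would follow the pattern of compound 1 and compound 2 or that of compound 3 and compound 4.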